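The compounds below may be only part of what the source reports. "The series", "measured", "known", "first", "only" and "open" are said of these compounds alone.

Measured compounds:
Compound 1 `Cc1cn2c(/C=N/NC(=N)N)c(-c3ccncc3)nc2s1`: 34700 nM
Compound 2 `Cc1sc2nc(-c3ccncc3)c(/C=N/NC(=N)N)n2c1C`: 97700 nM

Compound 1 has the lowest number of the two measured in a functional assay on ovarian cells (Homo sapiens) for antiproliferative activity; on this read-out lower numbers stand for stronger inhibition of growth and higher numbers for weaker inhibition of growth; its nearest neighbour is compound 2, reached by the step of a 2.8-fold higher number from compound 1 to compound 2 (0.45 log units; beyond the scatter), which comes from putting a methyl in place of hydrogen on an aromatic carbon. Compound 3 `Cc1cn2c(/C=N/NC(=N)N)c(-c3cccnc3)nc2s1` has not yet been measured. It differs from compound 1 by pyridin-3-yl in place of pyridin-4-yl on an aromatic carbon. Going by the values given here, no measured step concerns the pyridyl ring at all: the single step from compound 1 to compound 2 changes only the methyl pattern on the shared core, so it offers no direct guide to the exchange of one pyridyl attachment for another. With nothing in the data pointing either way, he expects the change to compound 3 to stay close to compound 1, that is a step of about a 1.2-fold higher number from compound 1 to compound 3 (0.06 log units; within the scatter), not beyond the scatter. His estimate for compound 3 in this assay is therefore 40000 nM, within a range from 15000 nM to 110000 nM.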

Compound 3, concentration for total growth inhibition: 36300 nM
The estimate for compound 3 lay 1.1-fold (0.04 log units) above the measured number; measured number inside the range.
By their numbers in this assay, from the lowest: compounds 1 and 3 (each within the scatter of the next); then compound 2.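

In this assay, going by these compounds alone, the exchange of pyridin-4-yl for pyridin-3-yl gives the first reading on the pyridyl group itself, on an aromatic carbon of the five-membered aromatic ring of the shared core: a 1.0-fold higher number from compound 1 to compound 3 (0.02 log units; within the scatter). Within the data shown here, on this read-out, then, the attachment point of the pyridyl ring can be exchanged between these two forms without a difference that can be told from the scatter, whereas the only step beyond the scatter so far remains the added methyl on the core, a 2.8-fold higher number from compound 1 to compound 2 (0.45 log units; beyond the scatter). Nothing measured here offers an explanation for why the two pyridyl isomers read alike.

As far as these compounds go, what remains open is whether the ring nitrogen of the pyridyl group matters at all, since both groups carry one, and a plain phenyl ring or pyridin-2-yl at this carbon would be needed to answer that. From the compounds shown here alone, it is also open whether a substituent on the pyridyl ring, such as an amine or a methoxy group, would move the number in this assay, or whether the added methyl has the same effect with pyridin-3-yl in place.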